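Acetyl removal steps in a cytotoxicity series

The compounds below may be only part of what the source reports. "The series", "measured", "known", "first", "only" and "open" are said of these compounds alone.

Compound 1 `C=C1CC[C@@H]2[C@](C)(COC(C)=O)[C@H](OC(C)=O)CC[C@@]2(C)[C@@H]1C/C=C1/C(=O)OC[C@H]1OC(C)=O` gives 11.4 uM in a functional assay on ASK cells (Rattus norvegicus) for cytotoxicity, read by sulforhodamine B assay; a higher number here means that more compound is needed for the effect, a lower number that less compound is needed. Compound 3 `C=C1CC[C@@H]2[C@](C)(CO)[C@H](OC(C)=O)CC[C@@]2(C)[C@@H]1C/C=C1/C(=O)OC[C@H]1OC(C)=O` gives 11.5 uM in this assay. The two differ in one place: hydrogen in place of acetyl on an oxygen on a saturated carbon This change moved the number by a 1.0-fold higher number from compound 1 to compound 3 (0.00 log units; within the scatter).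

Compound 2 `C=C1CC[C@@H]2[C@](C)(CO[Si](c3ccccc3)(c3ccccc3)C(C)(C)C)[C@H](OC(C)=O)CC[C@@]2(C)[C@@H]1C/C=C1/C(=O)OC[C@H]1O` gives 10.5 uM in this assay; the difference between the core of compound 2 and the core of compound 1 is not broken down here. Compound 4 `C=C1CC[C@@H]2[C@](C)(CO[Si](c3ccccc3)(c3ccccc3)C(C)(C)C)[C@H](O)CC[C@@]2(C)[C@@H]1C/C=C1/C(=O)OC[C@H]1O` is not yet measured. It differs from compound 2 in one place: hydrogen in place of acetyl on an oxygen on a saturated carbon This is the same kind of change as from compound 1 to compound 3, not the same: there the oxygen sat on a saturated carbon whose other neighbour is a saturated chain carbon, whereas here the other neighbour is a saturated ring carbon, so the earlier change also read acetoxymethyl to hydroxymethyl.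

Beside the earlier step of a 1.0-fold higher number from compound 1 to compound 3 (0.00 log units; within the scatter), the expected step from compound 2 to compound 4 in this assay is no change at the digits printed from compound 2 to compound 4 (within the scatter), resting on compound 2 at 10.5 uM and on the earlier acetyl removal leaving the number unchanged. Compound 4 is therefore estimated at 10.5 uM, between 5 uM and 22 uM.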

Compound 4, concentration for half-maximal effect: 5.54 uM
The estimate for compound 4 lay 1.9-fold (0.28 log units) above the measured number; measured number inside the range.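

In this assay, hydrogen in place of acetyl gives a 1.9-fold lower number from compound 2 to compound 4 (0.28 log units; within the scatter). Set beside the earlier step on the other core, the change gives no sign of depending on the core: the same change on two cores in this assay, a 1.0-fold higher number (0.00 log units; within the scatter) from compound 1 to compound 3 and a 1.9-fold lower number (0.28 log units; within the scatter) from compound 2 to compound 4, 1.9-fold (0.28 log units) apart, within the scatter of two such steps. For the compounds shown here, this supports carrying the change between these two cores without a separate correction, but it rests on only two steps, both within the scatter, and it does not show that the change is without effect on other cores, nor that the two sites are equivalent, since one step reads acetoxymethyl to hydroxymethyl and the other acetoxy to hydroxy.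

The compounds shown leave open whether a longer chain on the same oxygen, such as butyryl or hexanoyl in place of acetyl, would also stay within the scatter in this assay. On these data alone, it is also open whether an amine or a carboxylic acid at the place of the hydroxy group would leave the number as close.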